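The compounds below may be only part of what the source reports. "The series", "measured", "known", "first", "only" and "open" are said of these compounds alone.

Working notes on the series.

Three compounds of the shared core have been run in a functional assay on PANC-1 cells (Homo sapiens) for inhibition, read by MTT assay, with a stated time of 72 h; on this read-out lower numbers stand for stronger inhibition of growth and higher numbers for weaker inhibition of growth. Compound 1 `O=S(=O)(NCCCNCc1ccccc1Cl)c1cc(C(F)(F)F)cc(C(F)(F)F)c1` gives 15000 nM. Compound 2 `O=S(=O)(NCCCNCc1ccc(Cl)c(Cl)c1)c1cc(C(F)(F)F)cc(C(F)(F)F)c1` gives 5600 nM. Compound 3 `O=S(=O)(NCCCNCc1ccc(Br)cc1)c1cc(C(F)(F)F)cc(C(F)(F)F)c1` gives 2200 nM, the lowest of the three numbers. The steps within the set are all beyond the scatter: a 2.7-fold lower number from compound 1 to compound 2 (0.43 log units; beyond the scatter), a 6.8-fold lower number from compound 1 to compound 3 (0.83 log units; beyond the scatter) and a 2.5-fold lower number from compound 2 to compound 3 (0.41 log units; beyond the scatter). Compound 3 thus stands apart from both of the others, with compound 2 nearest and compound 1 furthest from it.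

Compound 4 `O=S(=O)(NCCCNCc1ccc(Cl)cc1)c1cc(C(F)(F)F)cc(C(F)(F)F)c1` is not yet measured. The change from compound 3 is chloro in place of bromo on an aromatic carbon: bromo leaves and chloro enters on an aromatic carbon of the six-membered aromatic ring of carbon only, para to a large group. Among the compounds with values here, none of the measured steps swaps one halogen for another on the same aromatic carbon; the steps that reach compound 3 move or add halogens instead, and their sizes show that the halogen pattern on this ring matters in this assay. Compound 4 keeps the pattern of compound 3 and differs only in the halogen itself, so a step of small size is expected, a 1.4-fold higher number from compound 3 to compound 4 (0.13 log units; within the scatter), most likely within the scatter or a little toward the weaker side. Compound 4 is estimated at 3000 nM, within 1500 nM to 6500 nM.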

Compound 4, concentration for 50% growth inhibition: 4900 nM
Compound 4: the middle estimate sits 1.6-fold (0.21 log units) below what was measured; measured number inside the range.
By their numbers in this assay, from the lowest: compound 3; then compounds 4 and 2 (each within the scatter of the next); then compound 1.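

In this assay, the identity of the halogen matters at this position: with the pattern held, chloro in place of bromo on an aromatic carbon, para to a large group, gives a 2.2-fold higher number from compound 3 to compound 4 (0.35 log units; beyond the scatter) and leaves compound 3 apart from every other compound in the set. Hydrogen in place of chloro on an aromatic carbon gives a 1.1-fold lower number from compound 2 to compound 4 (0.06 log units; within the scatter) and so stays inside the usual scatter, which means the added chloro of compound 2 has no readable effect on this read-out. For a single chloro, its place on the ring does register, since 4-chlorophenyl in place of 2-chlorophenyl gives a 3.1-fold lower number from compound 1 to compound 4 (0.49 log units; beyond the scatter) and this separates the two monochloro compounds.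

The compounds shown leave open whether fluoro, iodo, methyl, methoxy or nitrile on the same aromatic carbon would fall in line with bromo and chloro, and whether the bromo and chloro difference would hold on a longer chain. Nothing at hand gives a measured basis for the difference between bromo and chloro at this position.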